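The source may hold more compounds than are shown below. What is called first, only, known or untested is meant among the compounds shown, and "the series" means these compounds.

Measured so far in an assay on isolated protein for inhibition of DNA topoisomerase 1 (Homo sapiens), with a stated time of 30 min, tested at 100 uM; on this read-out lower numbers stand for a weaker effect and higher numbers for a stronger effect at the one concentration tested:
- compound 1, `COc1cc(OC)cc(-c2cc3ccccc3c(-c3cccc(N)c3)n2)c1`: 0%
- compound 2, `COc1cc(OC)cc(-c2cc3ccccc3c(-c3ccc(O)cc3)n2)c1`: 0%
- compound 3, `COc1ccc(-c2cc3cc(C)ccc3c(-c3cccc(N)c3)n2)cc1OC`: 7.2%

Of the compounds shown here, three have been tested in this assay, and all three give readings that sit within the usual scatter of one another. Compound 1 carries a 3-aminophenyl group on its core, and in this assay compound 1 gives 0%. Compound 2 carries a 4-hydroxyphenyl group in its place, and compound 2 gives 0%. The structural change between them is 4-hydroxyphenyl in place of 3-aminophenyl on an aromatic carbon, and the measured step is no change at the digits printed from compound 1 to compound 2 (within the scatter). Compound 3 has a different core from compound 1; how the two cores differ is not broken down here. Compound 3 gives 7.2%.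

Compound 4, `COc1ccc(-c2cc3cc(C)ccc3c(-c3ccc(O)cc3)n2)cc1OC`, has not yet been measured. It relates to compound 3 as compound 2 relates to compound 1: the change is 4-hydroxyphenyl in place of 3-aminophenyl on an aromatic carbon, and the surroundings of the place where the change is made are described in the same words for both pairs, so this is the same change applied to a second core.

For the measured compounds named here, the one measured example of this change, from compound 1 to compound 2, did not move the reading out of the scatter, so the expected step from compound 3 to compound 4 is likewise small, estimated as a number 2.2 percentage points lower from compound 3 to compound 4 (within the scatter). For compound 4 the estimated inhibition in this assay is 5%, expected to fall between 0% and 15%.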

Compound 4, a percentage reported as inhibition, at one concentration (the size of the read-out at that concentration, not a potency): 0.3%
Beside the measured number, compound 4's estimate is 4.7 percentage points above it; the range from low to high includes it.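

Putting 4-hydroxyphenyl in place of 3-aminophenyl on the core of compound 3 gives, in this assay, a number 6.9 percentage points lower from compound 3 to compound 4 (within the scatter), which is a step no larger than repeated measurements of this kind would be expected to produce. Set beside the first example of the same swap, the two steps agree, and the change can be said to carry from one core to the other as far as this read-out can tell: the same change on two cores in this assay, no change at the digits printed (within the scatter) from compound 1 to compound 2 and a number 6.9 percentage points lower (within the scatter) from compound 3 to compound 4, 6.9 percentage points apart, within the scatter of two such steps

This does not show that the two groups are interchangeable in general: all four readings are small and come from a single concentration, and two pairs cannot say how the change would behave on a core that gives a clear effect, nor do they give a potency for any compound.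

The compounds shown leave open whether any other group on this aromatic carbon, such as a carboxylic acid, a simple amine or a longer chain, would give a reading beyond the scatter. They also leave open what each structural difference between the two cores contributes, as compound 1 and compound 3 differ in more than one place.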